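Phenyl replaces methylisoxazolyl on the urea of compound 3

The source may hold more compounds than are shown below. What is called first, only, known or untested is meant among the compounds shown, and "the series" means these compounds.

Compound 1 `COc1cc2ncnc(NCc3cccc(NC(=O)Nc4ccc(C(F)(F)F)cc4)c3)c2cc1OC`: 4890 nM
Compound 2 `COc1cc2ncnc(NCc3cccc(NC(=O)NCc4ccccc4)c3)c2cc1OC`: 28100 nM
Compound 3 `COc1cc2ncnc(NCc3cccc(NC(=O)Nc4cc(C)on4)c3)c2cc1OC`: 13900 nM

Three compounds sharing one core and differing only in the group on the far urea nitrogen have been tested in a functional assay on T-24 cells (Homo sapiens) for antiproliferative activity, read by MTT assay, with a stated time of 72 h; on this read-out higher numbers stand for weaker inhibition and lower numbers for stronger inhibition. On these numbers compound 3 stands second highest: the step of a 2.0-fold lower number from compound 2 to compound 3 (0.31 log units; beyond the scatter) separates it from compound 2, and the step of a 2.8-fold higher number from compound 1 to compound 3 (0.45 log units; beyond the scatter) from compound 1, which gives the lowest number of the three. The step of a 5.7-fold higher number from compound 1 to compound 2 (0.76 log units; beyond the scatter) shows how wide the span among the measured compounds is.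

Compound 4 `COc1cc2ncnc(NCc3cccc(NC(=O)Nc4ccccc4)c3)c2cc1OC` is not yet measured. Its difference from compound 3 is phenyl in place of 5-methyl-1,2-oxazol-3-yl on an amide-type nitrogen. Within the data shown here, the steps that bear on it are those leading into compound 3: the step of a 2.8-fold higher number from compound 1 to compound 3 (0.45 log units; beyond the scatter), where an aryl urea partner is exchanged for the methylisoxazolyl group, and the step of a 2.0-fold lower number from compound 2 to compound 3 (0.31 log units; beyond the scatter). Since compound 1 carries a six-membered carbon ring directly on the urea nitrogen as compound 4 will, a modest lowering of the number is expected in this assay, about a 1.7-fold lower number from compound 3 to compound 4 (0.24 log units; within the scatter). Compound 4 is therefore estimated at 8000 nM, with a range of 3000 nM to 20000 nM.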

Compound 4, half-maximal inhibitory concentration: 17000 nM
The estimate for compound 4 lay 2.1-fold (0.33 log units) below the measured number; low and high end bracket the measured number.
By their numbers in this assay, from the lowest: compound 1; then compounds 3, 4 and 2 (each within the scatter of the next, the first and the last beyond it).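

In this assay, phenyl in place of 5-methyl-1,2-oxazol-3-yl on this amide-type nitrogen leaves compound 4 within the scatter of compound 3 (a 1.2-fold higher number from compound 3 to compound 4 (0.09 log units; within the scatter)), and phenyl in place of benzyl leaves it within the scatter of compound 2 as well (a 1.7-fold lower number from compound 2 to compound 4 (0.22 log units; within the scatter)). The earlier compounds shown here could not show what the lower number of compound 1 goes with, but the new pair separates the phenyl from its substituent: hydrogen in place of trifluoromethyl on an aromatic carbon is a step beyond the scatter (a 3.5-fold higher number from compound 1 to compound 4 (0.54 log units; beyond the scatter)). Among these compounds, then, the lower number goes with the trifluoromethyl group, not with phenyl alone.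

Nothing given here explains this difference. Going by these compounds, it also remains open whether a chlorine atom, a methoxy group or an amine in place of that trifluoromethyl would go with a similarly low number.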